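Replacing trifluoromethyl with carbamoyl on a diaryl urea

This account rests on a few compounds, and the source may have more. Where it says the series, first, only, none or still open, it means among the compounds named here.

Of the compounds shown here, three sharing one core have been measured in a physicochemical assay for solubility, at pH 7.4; a lower number here means a less soluble compound, a higher number a more soluble compound. Compound 1, `Cc1cc(NC(=O)Nc2ccccc2C(F)(F)F)c2ccccc2n1`, gives 3800 nM in this assay and stands highest of the three. Compound 2, `Cc1cc(NC(=O)Nc2ccc(O)cc2)c2ccccc2n1`, gives 100 nM, and compound 3, `Cc1cc(NC(=O)Nc2ccc(Cl)cc2Cl)c2ccccc2n1`, gives 100 nM; both lie well beyond the scatter of compound 1, at the same distance from it. No pair among these three differs in only one place, so no single change can be read off from the measured set.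

Compound 4, `Cc1cc(NC(=O)Nc2ccccc2C(N)=O)c2ccccc2n1`, has not been measured. It differs from compound 1 as follows: carbamoyl in place of trifluoromethyl on an aromatic carbon.

With no comparable change among the measured compounds, the expectation for compound 4 rests on compound 1 at 3800 nM alone. The step from compound 1 is expected to be small, within or near the scatter, in either direction: a 1.1-fold higher number from compound 1 to compound 4 (0.02 log units; within the scatter). Compound 4 is therefore estimated at 4000 nM in this assay, with a range from 1000 nM to 16000 nM.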

Compound 4, solubility: 200 nM
Beside the measured number, compound 4's estimate is 20-fold (1.30 log units) above it, and the stated range ends above it.
By their numbers in this assay, from the lowest: compounds 2, 3 and 4 (each within the scatter of the next); then compound 1.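

In this assay, carbamoyl in place of trifluoromethyl on an aromatic carbon, ortho to a large group, brings a 19-fold lower number from compound 1 to compound 4 (1.28 log units; beyond the scatter). For the compounds shown here, this is the first single change that can be read, and it shows that the number is sensitive to which group stands at this position: here the entering group, with one hydrogen-bond donor and one acceptor, goes with the lower number. Nothing measured here accounts for the size of the step.

On these data alone, whether the step belongs to carbamoyl alone or would also follow from a nitrile, an amine or a carboxylic acid at this position remains open. So does whether the same exchange would give a step of this size elsewhere on the aromatic ring, since one pair sets no pattern.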